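Thiazolyl ketone sulfides: antiproliferative read-out and a dechloro analogue

This account rests on a few compounds, and the source may have more. Where it says the series, first, only, none or still open, it means among the compounds named here.

Measured so far:
compound 1 `Cc1nc(-c2ccc(Cl)cc2)sc1C(=O)CSc1nc(-c2ccc(Cl)c(Cl)c2)c(C#N)c(=O)[nH]1`: 101%
compound 2 `Cc1nc(-c2ccc(Cl)cc2)sc1C(=O)CSc1nc(N)c(C#N)c(-c2ccc(Cl)cc2)n1`: 46.1%
compound 3 `COc1ccc(-c2nc(C)c(C(=O)CSc3nc(-c4ccc(OC)cc4)c(C#N)c(=O)[nH]3)s2)cc1`: 97%

In a functional assay on U-87MG ATCC cells for antiproliferative activity against U-87 MG (Homo sapiens), read by MTT assay, with a stated time of 48 h, tested at 5 uM (a higher number here means a weaker effect of the compound at the concentration tested, a lower number a stronger effect), compound 2 gives the lowest number of the three, and both other numbers lie beyond the scatter above it: compound 1 gives 101% and compound 3 gives 97%. Compound 1 and compound 3 differ from compound 2 in more than one place, so their gaps to compound 2 cannot be tied to a single change.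

Compound 4 `Cc1nc(-c2ccccc2)sc1C(=O)CSc1nc(N)c(C#N)c(-c2ccc(Cl)cc2)n1` is not yet measured. It differs from compound 2 in one place: hydrogen in place of chloro on an aromatic carbon. Among the compounds with values here, no single-place step between measured compounds is available, so the effect of this change is untested here. The step is expected to be small, at most a modest move toward a higher number in this assay, roughly a number 9.9 percentage points higher from compound 2 to compound 4 (within the scatter). Compound 4 is therefore estimated at 56% in this assay, within 36% to 80%.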

Compound 4, a percentage reported as activity, at one concentration (the size of the read-out at that concentration, not a potency): 62.9%
For compound 4 the middle estimate is 6.9 percentage points below the measured one; measured number inside the range.
By their numbers in this assay, from the lowest: compound 2; then compound 4; then compounds 3 and 1 (each within the scatter of the next).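

In this assay, within the data shown here, the 4-chlorophenyl to phenyl change gives a number 16.8 percentage points higher from compound 2 to compound 4 (beyond the scatter), the first single-place step. Among these compounds, it shows that, at this carbon, removing the chloro shifts the read-out beyond the scatter, which the earlier compounds, all differing in more than one place, could not show. Nothing available here explains this step.

Still open, from the compounds shown here alone, is how a fluoro, a bromo, a methyl or a trifluoromethyl group would read at the same carbon. A single step also leaves open whether this change would shift the read-out similarly on the core of compound 1 or compound 3.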